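The compounds below may be only part of what the source reports. "The series", "measured", "known", "first", "only" and "open" are said of these compounds alone.

Compound 1, `CCSC(=S)N[C@H]1CCOC1=O`: in a functional assay on EC9706 cells (Homo sapiens) for cytotoxicity, read by MTT assay, with a stated time of 72 h (on this read-out lower numbers stand for stronger inhibition and higher numbers for weaker inhibition), it reaches only a limit of the assay, > 128000 nM.
Compound 2, `CCCCCCSC(=S)N[C@H]1CCOC1=O`: in this assay it likewise reaches only a limit of the assay, > 128000 nM.

Both measured values are limits rather than numbers, so the step that the two limits leave unreadable from compound 1 to compound 2 cannot be read; both compounds sit at the limit of > 128000 nM in this assay, at which 2 of the 2 values shown sit, and that is where compound 2 stands. Compound 3, `CCCCCCCCCCCCSC(=S)N[C@H]1CCOC1=O`, extends the same chain further: hexyl in place of hydrogen on a saturated chain carbon, six bonds along the chain from a sulfur. Among the measured compounds shown here, the only measured step concerns lengthening of this chain, and it is unreadable, so it gives no reason to expect compound 3 to move away from the limit. The step that the limit leaves unreadable from compound 2 to compound 3 is therefore expected to be none beyond the scatter, and most likely compound 3 will again be reported only as a limit. Compound 3 is estimated at 200000 nM, within a range from 100000 nM to 1000000 nM.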

Compound 3, half-maximal inhibitory concentration: 58300 nM
Compound 3: middle estimate off by 3.4-fold (0.54 log units), on the high side; measured number below the stated range.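

Adding hexyl on a saturated chain carbon, six bonds along the chain from a sulfur, yields the first real number in this assay, with an at least 2.1-fold lower number from compound 2 to compound 3 (0.34 log units; beyond the scatter), so this place in the series does respond to a change in chain length. The earlier step, where the chain grew by butyl, cannot be read, which leaves this as the only sign of any response. The new step gives only a minimum size, because compound 2 reaches just a limit of the assay: the limit of > 128000 nM in this assay, at which 2 of the 3 values shown sit.

Going by these compounds, whether a longer chain than that of compound 3 would lower the number further remains open, as does the chain length at which a number first appears. Also open, on these data alone, is whether an amine or a carboxylic acid at the end of the chain would keep the gain.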